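The source may report more compounds than this note shows. Statements on the series, on what has been measured and on what is new or still open speak of the compounds shown alone.

Two compounds of the shared core have numbers in an assay on isolated protein for inhibition of NUAK family SNF1-like kinase 2 (Homo sapiens), read by ADP-Glo, with a stated time of 60 min, tested at 10 uM, in the presence of a further agent that is not named here; on this read-out higher numbers stand for more inhibition at the one concentration tested (going by the name of the read-out) and lower numbers for less inhibition. Compound 1 `CCC(=O)Nc1cccc(Oc2nc(Nc3ccc(N(C)C)cc3OC)ncc2Cl)c1` gives 15%. Among the measured compounds shown here, compound 2 `CCC(=O)Nc1cccc(Oc2nc(Nc3ccc(N4CCCCC4)cc3)ncc2Cl)c1` gives 72.3%, the higher of the two numbers, and the gap to compound 1 lies beyond the scatter; compound 1 and compound 2 differ in two places, so the pair shows only that the two values sit far apart. Compound 3 `CCC(=O)Nc1cccc(Oc2nc(Nc3ccc(N4CCCCC4)cc3OC)ncc2Cl)c1` is not yet measured in this assay. Its change from compound 2: methoxy in place of hydrogen on an aromatic carbon. For the measured compounds named here, no step between measured compounds isolates this change. Compound 1, which also carries a methoxy, gives the lower value 15%, but a second difference stands in the way, so the direction rests on weak ground. A moderate drop is expected, a number 17.3 percentage points lower from compound 2 to compound 3 (beyond the scatter), with wide uncertainty. Compound 3 is estimated at 55%, between 25% and 80%.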

Compound 3, a percentage reported as inhibition, at one concentration (the size of the read-out at that concentration, not a potency): "not active" (no number reported)
Nothing numeric was reported for compound 3; there is nothing to compare the estimate with.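

Among the compounds shown here, compound 3 is recorded as not active in this assay, without a number, so no step from compound 2 to compound 3 can be read. The compounds shown leave open how far methoxy alone shifts inhibition on compound 2. No available data bear on the cause of this result.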